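Adding a Methoxy Group to Three Compounds Without Measurable Cytotoxicity

The compounds below may be only part of what the source reports. "The series", "measured", "known", "first", "only" and "open" are said of these compounds alone.

Compound 1 `COc1ccc(CNc2ncnc3c2ncn3C2CCCCO2)cc1OC` gives > 100000 nM in an ADME assay on K562 cells (Homo sapiens) for cytotoxicity, with a stated time of 72 h; on this read-out lower numbers stand for stronger inhibition and higher numbers for weaker inhibition.
Compound 2 `COc1cc(CNc2ncnc3c2ncn3C2CCCCO2)cc(OC)c1OC` gives > 100000 nM in this assay.
Compound 3 `COc1ccc(OC)c(CNc2ncnc3c2ncn3C2CCCO2)c1` gives > 50000 nM in this assay.

Each of these three values is a limit of the assay, not a number. Compound 2 differs from compound 1 by methoxy in place of hydrogen on an aromatic carbon, and the step that the two limits leave unreadable from compound 1 to compound 2 cannot be sized, since both ends are limits (the limit of > 100000 nM in this assay, at which 2 of the 3 values shown sit). The difference between the cores of compound 1 and compound 3 is not broken down here. Compound 4 `COc1cc(OC)c(OC)cc1CNc1ncnc2c1ncn2C1CCCO1` differs from compound 3 by the same kind of change, (methoxy in place of hydrogen on an aromatic carbon); its place differs in being para to a large group rather than meta to a large group. Compound 4 is expected to stay at a limit as well, a step that the limit leaves unreadable from compound 3 to compound 4 that is expected to be no larger than the scatter, because compound 3 sits at > 50000 nM the limit of > 50000 nM in this assay, at which 1 of the 3 values shown sits, and compound 2 at > 100000 nM. The estimate for compound 4 is 100000 nM, spanning 30000 nM to 300000 nM.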

Compound 4, half-maximal inhibitory concentration: > 100000 nM
Compound 4: no number, only a limit; the forecaster's own chance of this, stated with the estimate: 80%; the middle value sits exactly at the limit.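

The values of compound 3 and compound 4 are both limits in this assay, and the step between them cannot be read. The compounds shown leave open whether methoxy in place of hydrogen on an aromatic carbon changes cytotoxicity at all.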